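Adding a Cyano Group to Compound 3

A few compounds are considered here, and "the series" means these few. Any claim that something is new, unique, unknown or untested is made for them only; others in the source may bear on it.

Measured so far in a functional assay on the whole organism for inhibition, with Rattus norvegicus as the target, at a dose of 30 mg/kg by the intraperitoneal route; a lower number here means less inhibition, a higher number more inhibition at the dose given (going by the name of the read-out):
compound 1, `Cn1cnc2ncnn2c1=S`, gives 69%
compound 2, `CCCCn1cnc2ncnn2c1=S`, gives 23%
compound 3, `Cn1cnc2nc(-c3ccccc3)nn2c1=S`, gives 1%

Of the compounds shown here, three share a core and have been measured in this assay. Compound 3 stands lowest of the three numbers: compound 2 is the nearest to it, and compound 1, the furthest, shows a far higher number. Going by the values given here, the one step between two compounds that differ in a single place is a number 46 percentage points lower from compound 1 to compound 2 (beyond the scatter), and it concerns propyl in place of hydrogen on a saturated chain carbon bound to an aromatic nitrogen. That step says nothing about what happens when a six-membered aromatic ring of carbon only is changed.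

Compound 4, `Cn1cnc2nc(-c3ccc(C#N)cc3)nn2c1=S`, differs from compound 3 by cyano in place of hydrogen on an aromatic carbon. Among the compounds with values here, no measured step bears on a change of this kind, so the expectation for it rests on the position of compound 3 alone, whose number is already close to the bottom of the scale. Compound 4 is therefore expected to give 5%, in a range from 0% to 20%. The expected step is a number 4 percentage points higher from compound 3 to compound 4 (within the scatter), which is no step beyond the scatter.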

Compound 4, a percentage reported as inhibition, in the whole organism at one dose (the size of the read-out at that dose, not a potency): 79%
For compound 4 the middle estimate is 74 percentage points below the measured one; measured number outside the range, above it.
By their numbers in this assay, from the lowest: compound 3; then compound 2; then compounds 1 and 4 (each within the scatter of the next).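

In this assay, cyano in place of hydrogen on an aromatic carbon, para to a large group, goes with a number 78 percentage points higher from compound 3 to compound 4 (beyond the scatter) and is the first change shown on the six-membered aromatic ring of carbon only. A group of just 2 heavy atoms at this place thus separates almost no inhibition from a high reading at this single dose, and compound 1 at 69% and compound 4 at 79% lie within the scatter of each other, so a ring on the shared core can go with a high reading when it carries this group. Nothing shown here gives a reason for the size of this step.

The compounds shown leave open whether the high reading belongs to cyano itself or would also appear with another group at this place, such as a chlorine atom, a methoxy group, an amine or a carboxylic acid. They also leave open how the cyano-bearing ring would behave with butyl in place of the methyl of compound 4, and how the compounds would compare across a range of doses rather than at this one.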